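An Ethynyl Group Added to the Anilide of Compound 3

The source may hold more compounds than are shown below. What is called first, only, known or untested is meant among the compounds shown, and "the series" means these compounds.

Measured so far:
Compound 1 `O=C(O)CCc1cccc2c1B(O)OC2`, in a functional assay on HCT-116 cells (Homo sapiens) for antiproliferative activity, read by MTT assay, with a stated time of 72 h (on this read-out lower numbers stand for stronger inhibition and higher numbers for weaker inhibition), only the assay's limit of > 100000 nM.
Compound 2 `CC(C)(C)NC(=O)CCc1cccc2c1B(O)OC2`, in this assay, again only a limit of > 100000 nM.
Compound 3 `O=C(CCc1cccc2c1B(O)OC2)Nc1ccccc1`, in this assay, 350 nM.

Compound 3 therefore holds the only real number shown; the other two values are limits. Compound 4 `C#Cc1ccc(NC(=O)CCc2cccc3c2B(O)OC3)cc1` differs from it by ethynyl in place of hydrogen on an aromatic carbon. The measured steps, an at least 280-fold lower number from compound 1 to compound 3 (2.45 log units; beyond the scatter) and an at least 280-fold lower number from compound 2 to compound 3 (2.45 log units; beyond the scatter), concern the group on the carbonyl carbon, which compound 4 keeps unchanged, so none of them speaks directly to an ethynyl on the aromatic ring. A step within the scatter is expected, a 1.4-fold lower number from compound 3 to compound 4 (0.15 log units; within the scatter). Compound 4 is estimated at 250 nM, in the range 80 nM to 800 nM.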

Compound 4, half-maximal inhibitory concentration: 45000 nM
For compound 4 the middle estimate is 180-fold (2.26 log units) below the measured one, and the stated range ends below it.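

Ethynyl in place of hydrogen on an aromatic carbon, para to a large group, gives a 130-fold higher number from compound 3 to compound 4 (2.11 log units; beyond the scatter) in this assay. The earlier steps shown here changed only the group on the carbonyl carbon, whereas this one shows that a change on the aromatic ring of compound 3 alone can cost much of its activity. Compound 4 still gives a real number rather than the limit: the limit of > 100000 nM in this assay, at which 2 of the 4 values shown sit.

Going by these compounds, whether the loss is specific to ethynyl remains open. A methyl, a methoxy or an amine at this position could behave differently, as could ethynyl on another ring carbon.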